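From Iodo to Hydrogen on the Shared Core

The source may report more compounds than this note shows. Statements on the series, on what has been measured and on what is new or still open speak of the compounds shown alone.

In a functional assay on MCF7 cells (Homo sapiens) for inhibition (on this read-out higher numbers stand for weaker inhibition and lower numbers for stronger inhibition), compound 1 (`O=C1O/C(=C\Cn2cc(C(F)(F)F)c(=O)[nH]c2=O)C(OCc2ccccc2)=C1OCc1ccccc1`) gives 40000 nM and compound 2 (`O=C1O/C(=C\Cn2cc(I)c(=O)[nH]c2=O)C(OCc2ccccc2)=C1OCc1ccccc1`) gives 70000 nM. Of only these two numbers, compound 2 stands within the scatter of compound 1, so neither can be ranked over the other. Compound 3 (`O=C1O/C(=C\Cn2ccc(=O)[nH]c2=O)C(OCc2ccccc2)=C1OCc1ccccc1`) has hydrogen in place of iodo on an aromatic carbon. Going by the values given here, only one measured step bears on this carbon, where iodo replaces trifluoromethyl, and it is small: a 1.8-fold higher number from compound 1 to compound 2 (0.24 log units; within the scatter). Among the compounds with values here, no measured compound yet carries hydrogen there, so this single step is a thin guide. On that basis, no change beyond the scatter is expected in this assay. The estimated step is a 1.4-fold lower number from compound 2 to compound 3 (0.15 log units; within the scatter). For compound 3 the expected value is 50000 nM, with an estimated range of 20000 nM to 120000 nM.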

Compound 3, half-maximal inhibitory concentration: 20000 nM
Compound 3: middle estimate off by 2.5-fold (0.40 log units), on the high side; low and high end bracket the measured number.
By their numbers in this assay, from the lowest: compounds 3, 1 and 2 (each within the scatter of the next, the first and the last beyond it).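

In this assay, going by these compounds alone, hydrogen in place of iodo on this aromatic carbon gives the only step among the three compounds that lies beyond the scatter, and it is a modest one (a 3.5-fold lower number from compound 2 to compound 3 (0.54 log units; beyond the scatter)). Hydrogen in place of trifluoromethyl on the same carbon stays within the scatter (a 2.0-fold lower number from compound 1 to compound 3 (0.30 log units; within the scatter)), so this position separates only the iodo and hydrogen compounds, and trifluoromethyl cannot be told apart from either. Nothing measured here explains why the iodo compound differs from the hydrogen compound.

The compounds shown leave open whether an amine, a carboxylic acid or a longer chain on this carbon would move the number further than iodo or hydrogen does. They also leave open whether the same step would appear with the benzyl ether groups of the shared core replaced by hydroxyl groups.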